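The source may report more compounds than this note shows. Statements on the series, on what has been measured and on what is new or still open speak of the compounds shown alone.

In a functional assay on MiaPaCa cells (Homo sapiens) for antiproliferative activity, read by sulforhodamine B assay, with a stated time of 48 h (on this read-out higher numbers stand for weaker inhibition of growth and lower numbers for stronger inhibition of growth), compound 3 (`CCCc1cn(CCCN2C(=O)COc3ccccc32)nn1`) gives 2600 nM and holds the middle place of three numbers. Compound 2 (`O=C1COc2ccccc2N1CCCn1cc(CO)nn1`) sits lower at 1010 nM and compound 1 (`COc1ccc(-c2cn(CCCN3C(=O)COc4ccccc43)nn2)cc1`) sits highest at 15700 nM on the same read-out. Compound 4 (`O=C1COc2ccccc2N1CCCn1cc(CCCCl)nn1`) turns propyl into 3-chloropropyl, and chloro in place of hydrogen on a saturated chain carbon, three bonds along the chain from an aromatic carbon is the whole difference. Among the measured compounds shown here, no measured step makes this change. Replacing 4-methoxyphenyl gave larger moves, a 16-fold lower number from compound 1 to compound 2 (1.19 log units; beyond the scatter) and a 6.0-fold lower number from compound 1 to compound 3 (0.78 log units; beyond the scatter), whereas the closest comparison, a 2.6-fold higher number from compound 2 to compound 3 (0.41 log units; beyond the scatter), was modest and involved only a chain. A step beyond the scatter is therefore not expected in this assay, and no direction is favoured. The estimated step is a 1.2-fold lower number from compound 3 to compound 4 (0.07 log units; within the scatter) in size. Compound 4 is expected at 2200 nM as an estimate, with a range from 800 nM to 6000 nM.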

Compound 4, concentration for 50% growth inhibition: 12500 nM
For compound 4 the middle estimate is 5.7-fold (0.75 log units) below the measured one; measured number outside the range, above it.
By their numbers in this assay, from the lowest: compound 2; then compound 3; then compounds 4 and 1 (each within the scatter of the next).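

In this assay, one chloro on the end carbon of the propyl chain moves the number beyond the scatter (a 4.8-fold higher number from compound 3 to compound 4 (0.68 log units; beyond the scatter)), so this far end of the chain is not indifferent to change. The 3-chloropropyl chain also stands well apart from hydroxymethyl (a 12-fold higher number from compound 2 to compound 4 (1.09 log units; beyond the scatter)), yet lies within the scatter of 4-methoxyphenyl (a 1.3-fold lower number from compound 1 to compound 4 (0.10 log units; within the scatter)). No measured evidence accounts for the chloro step. From the compounds shown here alone, whether an amine or a carboxylic acid on that same end carbon would give a lower or a higher number remains open.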